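A Mirror Image Awaits Its Cytotoxicity Reading

The source may report more compounds than this note shows. Statements on the series, on what has been measured and on what is new or still open speak of the compounds shown alone.

Of the compounds shown here, two have been measured so far in an ADME assay on MDCK cells (Canis lupus familiaris) for cytotoxicity, read by MTT assay, with a stated time of 48 h; on this read-out higher numbers stand for lower toxicity in this test and lower numbers for higher toxicity in this test. Compound 1 `CC1(C)[C@H]2CC=C(COc3ccc4ccc(=O)oc4c3)[C@@H]1C2` gives 310000 nM in this test. Compound 2 `Cc1cc(=O)oc2cc(OCC3=CC[C@@H]4C[C@H]3C4(C)C)ccc12` gives 130000 nM in the same test. Compound 2 therefore holds the lower of the two numbers, and its gap to compound 1 lies beyond the usual scatter of repeated measurements.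

The next compound to be tested is compound 3 `Cc1cc(=O)oc2cc(OCC3=CC[C@H]4C[C@@H]3C4(C)C)ccc12`, and its difference from compound 2 is this: the two compounds have the same atoms and bonds and differ only in configuration as drawn: 2 of 2 stereo elements differ (all stereocentres are inverted: mirror images); a stereocentre at a saturated ring carbon is drawn R in compound 2 and S in compound 3; a stereocentre at a saturated ring carbon is drawn S in compound 2 and R in compound 3. The two are mirror images, with no atom or bond gained or lost. Among the compounds with values here, no mirror-image pair has yet been measured here, so the data offer no direct guide to the size of such a step. The working expectation is therefore no step beyond the scatter in this assay, in either direction, and it takes compound 2 at 130000 nM as its anchor. The expected step is no change at the digits printed from compound 2 to compound 3 (within the scatter) in this test. For compound 3 the estimated value is 130000 nM, with an expected range from 65000 nM to 280000 nM.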

Compound 3, half-maximal cytotoxic concentration: 30000 nM
Compound 3: the middle estimate sits 4.3-fold (0.64 log units) above what was measured; the measured number lies below the stated range.
By their numbers in this assay, from the lowest: compound 3; then compound 2; then compound 1.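

Configuration alone counts in this assay: no atom or bond changes, yet the inversion of both stereocentres gives a 4.3-fold lower number from compound 2 to compound 3 (0.64 log units; beyond the scatter). The step can be tied to those two saturated ring carbons and to nothing else because of what the two structures show: the fact that compounds 2 and 3 differ only in the configuration as drawn. Within the data shown here, compound 3 also gives the first reading of methyl in place of hydrogen on an aromatic carbon, with a 10-fold lower number from compound 1 to compound 3 (1.01 log units; beyond the scatter), and since its steps to both other compounds lie beyond the scatter, it stands as the most toxic of the three in this test.

The compounds shown leave open whether the gap between mirror images would persist with hydrogen rather than methyl on the aromatic carbon, so the size of the methyl step may belong to this one configuration only. They also leave open how the test would respond to a larger change at that aromatic carbon, such as an amine or a carboxylic acid in place of the methyl, in either mirror-image series.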